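Amide substituent swap on a vitamin D receptor agonist core

This account rests on a few compounds, and the source may have more. Where it says the series, first, only, none or still open, it means among the compounds named here.

Measured compounds:
compound 1, `CCn1c(C(=O)NCCN(C)C)ccc1C(CC)(CC)c1ccc(OCCC(O)(CC)CC)c(C)c1`: 82 nM
compound 2, `C=CCN(C)C(=O)c1ccc(C(CC)(CC)c2ccc(OCCC(O)(CC)CC)c(C)c2)n1CC`: > 10000 nM
compound 3, `CCC(C)C(NC(=O)c1ccc(C(CC)(CC)c2ccc(OCCC(O)(CC)CC)c(C)c2)n1CC)C(=O)O`: 860 nM

All three share one core and differ only in the group carried by the carbonyl carbon of the amide. In an assay on cells for agonist activity at vitamin D3 receptor (Homo sapiens), with a stated time of 96 h (on this read-out higher numbers stand for an effect only at larger amounts of compound and lower numbers for an effect already at smaller amounts), compound 1 gives 82 nM. For compound 2 the result is a limit of the assay and not a number, > 10000 nM; this is the limit of > 10000 nM in this assay, at which 1 of the 3 values shown sits. Compound 3 gives 860 nM, the highest of the two numbers shown, with a 10-fold higher number from compound 1 to compound 3 (1.02 log units; beyond the scatter) and an at least 11-fold lower number from compound 2 to compound 3 (1.06 log units; beyond the scatter).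

Compound 4, `CCn1c(C(=O)NC(C)CO)ccc1C(CC)(CC)c1ccc(OCCC(O)(CC)CC)c(C)c1`, is not yet measured. It differs from compound 3 by 1-(hydroxymethyl)ethyl in place of 1-carboxy-2-methylbutyl on an amide-type nitrogen. Going by the values given here, the steps that bear on it are those that alter the same amide nitrogen: a 10-fold higher number from compound 1 to compound 3 (1.02 log units; beyond the scatter) and an at least 120-fold higher number from compound 1 to compound 2 (2.08 log units; beyond the scatter). Both show that this position moves the read-out strongly, in either direction. A smaller neutral group carrying one hydroxyl is expected to land between compound 1 and compound 3, with the step of a 2.9-fold lower number from compound 3 to compound 4 (0.46 log units; beyond the scatter). Compound 4 is therefore estimated at 300 nM, within 60 nM to 2000 nM.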

Compound 4, half-maximal effective concentration: 96 nM
Compound 4: the middle estimate sits 3.1-fold (0.49 log units) above what was measured; the range from low to high includes it.
By their numbers in this assay, from the lowest: compounds 1 and 4 (each within the scatter of the next); then compound 3. At a limit, above all of these: compound 2.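

Compound 4 carries no dimethylamino group, yet in this assay the swap from compound 1 stays within the scatter, a 1.2-fold higher number from compound 1 to compound 4 (0.07 log units; within the scatter), so a chain ending in a hydroxyl can stand in for that amine at this amide nitrogen. Replacing 1-carboxy-2-methylbutyl with 1-(hydroxymethyl)ethyl gives a 9.0-fold lower number from compound 3 to compound 4 (0.95 log units; beyond the scatter), which ties the higher number of compound 3 to its own group and not simply to the missing dimethylamino group. The step of an at least 100-fold lower number from compound 2 to compound 4 (2.01 log units; beyond the scatter) starts from a limit of the assay and not a number: the limit of > 10000 nM in this assay, at which 1 of the 4 values shown sits.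

On these data alone, whether compound 3 owes its higher number to the carboxylic acid or to the longer branched chain stays open, and a short chain carrying a carboxylic acid would separate the two. Also open, as far as these compounds go, is whether the allyl group or the methyl on the amide nitrogen matters more in compound 2.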